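Loss of a Chloro Group in a Weakly Active Pair

This account rests on a few compounds, and the source may have more. Where it says the series, first, only, none or still open, it means among the compounds named here.

Compound 2 `O=C1C(N2CCCCC2)=NN(c2ccc(Cl)cc2)CN1c1ccccc1Cl` was tested in an ADME assay on HUVEC cells (Homo sapiens) for antiproliferative activity, read by resazurin assay, with a stated time of 72 h (on this read-out higher numbers stand for weaker inhibition of growth and lower numbers for stronger inhibition of growth), where compound 2 reached only a limit, > 50 ug/mL. This value sits at the limit of > 50 ug/mL in this assay, at which 1 of the 2 values shown sits, so its true position is not known. Compound 1 `O=C1C(N2CCCC2)=NN(c2ccccc2)CN1c1ccccc1Cl` gave 40.9 ug/mL in this assay. Compound 3 `O=C1C(N2CCCCC2)=NN(c2ccccc2)CN1c1ccccc1Cl` differs from compound 2 by hydrogen in place of chloro on an aromatic carbon. Going by the values given here, with no measured step available, and with compound 1 also weakly active at 40.9 ug/mL, the change is expected to stay within the scatter, an at least 1.1-fold lower number from compound 2 to compound 3 (0.04 log units; that floor lies within the scatter). Compound 3 is therefore estimated at 45 ug/mL, within a range from 25 ug/mL to 90 ug/mL, and a limit rather than a number remains likely.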

Compound 3, concentration for 50% growth inhibition in the HUVEC assay: 24.7 ug/mL
Compound 3: the middle estimate sits 1.8-fold (0.26 log units) above what was measured; measured number below the stated range.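

Going by these compounds, in the HUVEC assay, hydrogen in place of chloro gives an at least 2.0-fold lower number from compound 2 to compound 3 (0.30 log units; that floor lies within the scatter), a step whose true size stays unknown, as compound 2 stands only at a limit. At the other changed place, the HUVEC assay gives a 1.7-fold lower number from compound 1 to compound 3 (0.22 log units; within the scatter). In a physicochemical assay for lipophilicity, read by HPLC, measured as octanol-water partition (a lower number here means a more polar compound, a higher number a more lipophilic compound), compound 2 gives 5 and compound 3 gives 4.6, so the loss of chloro also registers there as a number 0.40 log units lower from compound 2 to compound 3 (beyond the scatter).

The compounds shown leave open how methoxy or an amine in place of chloro would read in the HUVEC assay. They also leave open whether the two shifts are linked.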